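Adding one methoxy group to compound 3

The source may report more compounds than this note shows. Statements on the series, on what has been measured and on what is new or still open speak of the compounds shown alone.

Compound 1 `COc1cc(/C=C2\CN(C)C/C(=C\c3ccc(Cl)c(Cl)c3)C2=O)cc(OC)c1`: 6900 nM
Compound 2 `COc1cc(/C=C2\CN(C)C/C(=C\c3cccc([N+](=O)[O-])c3)C2=O)cc(OC)c1`: 2560 nM
Compound 3 `COc1cc(/C=C2\CN(C)C/C(=C\c3ccc(C#N)cc3)C2=O)cc(OC)c1`: 3420 nM

These three compounds share a core and differ only in one aromatic group: 3,4-dichlorophenyl, 3-nitrophenyl or 4-cyanophenyl. In a functional assay on HeLa cells (Homo sapiens) for cytotoxicity, read by MTT assay, with a stated time of 24 h (a lower number here means a stronger inhibitor, a higher number a weaker inhibitor), compound 3 gives 3420 nM, a value that cannot be told apart from either of the other two: a 2.0-fold lower number from compound 1 to compound 3 (0.30 log units; within the scatter), and a 1.3-fold higher number from compound 2 to compound 3 (0.13 log units; within the scatter). For the measured compounds named here, only one step clears the scatter, and it is modest: a 2.7-fold lower number from compound 1 to compound 2 (0.43 log units; beyond the scatter).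

Compound 4 `COc1cc(/C=C2\CN(C)C/C(=C\c3ccc(C#N)cc3)C2=O)cc(OC)c1OC` keeps the 4-cyanophenyl group of compound 3 and changes its other aromatic ring. The change is methoxy in place of hydrogen on an aromatic carbon, ortho to two methoxy groups and para to a large group (methoxy in place of hydrogen on an aromatic carbon). Going by the values given here, none of the measured steps touches this ring, so none of them predicts the change directly. They show only how far the numbers in this assay moved when a different part of the molecule was swapped, and that movement was small. The data therefore support no direction, and no step beyond the scatter is expected. The expected step is a 1.1-fold lower number from compound 3 to compound 4 (0.06 log units; within the scatter). For compound 4 the estimated value is 3000 nM, with an expected range from 1200 nM to 7000 nM.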

Compound 4, half-maximal inhibitory concentration: 3420 nM
The estimate for compound 4 lay 1.1-fold (0.06 log units) below the measured number, within the range that was stated.
By their numbers in this assay, from the lowest: compounds 2, 3, 4 and 1 (each within the scatter of the next, the first and the last beyond it).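

Within this assay the step of no change at the digits printed from compound 3 to compound 4 (within the scatter) is the first reading on the ring that carries the methoxy groups, whereas the earlier compounds differed only in the other aromatic group. A methoxy group can stand in place of hydrogen on this aromatic carbon, ortho to two methoxy groups and para to a large group, without moving the number beyond the usual scatter, at least with the 4-cyanophenyl group in the molecule. Nothing shown gives a measured reason for this outcome.

For the compounds shown here, whether the same holds with the 3-nitrophenyl or 3,4-dichlorophenyl group stays open, as the only pair that differs by this methoxy group carries the 4-cyanophenyl group. Also open, as far as these compounds go, is how the number would respond to a different group on this same carbon, such as an amine, a hydroxyl group or a longer ether chain, since a single substitution cannot show whether this carbon tolerates change in general.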